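A few compounds are considered here, and "the series" means these few. Any claim that something is new, unique, unknown or untested is made for them only; others in the source may bear on it.

In a functional assay on cells for antagonist activity at C-C chemokine receptor type 4 (Homo sapiens), read by GTPgammaS binding (on this read-out lower numbers stand for stronger inhibition and higher numbers for weaker inhibition), compound 1 `O=S(=O)(Nc1ncnc2[nH]nc(O)c12)c1cccc(Cl)c1Cl` gives 15800 nM, compound 2 `COc1nn(C(C)C)c2ncnc(NS(=O)(=O)c3cccc(Cl)c3Cl)c12` gives 251 nM, and compound 3 `CNC(=O)Cn1nc(OC)c2c(NS(=O)(=O)c3cccc(Cl)c3Cl)ncnc21` gives 631 nM. Compound 3 thus holds the second highest number of the three, nearest to compound 2 and furthest from compound 1. Compound 4 `COc1nn(CCN(C)C)c2ncnc(NS(=O)(=O)c3cccc(Cl)c3Cl)c12` differs from compound 3 by (dimethylamino)methyl in place of methylcarbamoyl on a saturated chain carbon bound to an aromatic nitrogen. Among the measured compounds shown here, the only measured step touching this chain is a 2.5-fold higher number from compound 2 to compound 3 (0.40 log units; beyond the scatter), a modest shift. For the measured compounds named here, no measured pair exchanges an amide for an amine at this position, so in this assay a step of at most similar size, in either direction or none beyond the scatter, is expected. Compound 4 is therefore estimated at 500 nM, with a range from 160 nM to 1600 nM. This is expected to amount to a 1.3-fold lower number from compound 3 to compound 4 (0.10 log units; within the scatter).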

Compound 4, half-maximal inhibitory concentration: 3980 nM
Compound 4: middle estimate off by 8.0-fold (0.90 log units), on the low side; the measured number lies above the stated range.
By their numbers in this assay, from the lowest: compound 2; then compound 3; then compound 4; then compound 1.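

In this assay, among the compounds shown here, the chain on the aromatic nitrogen matters more than the earlier compounds showed: 2-(dimethylamino)ethyl gives a 6.3-fold higher number from compound 3 to compound 4 (0.80 log units; beyond the scatter) against (methylcarbamoyl)methyl, and a 16-fold higher number from compound 2 to compound 4 (1.20 log units; beyond the scatter) against isopropyl. With every step among the three beyond the scatter, the numbers rise from isopropyl through (methylcarbamoyl)methyl to 2-(dimethylamino)ethyl, so this position does not treat these chains alike. No evidence is available here to explain this order. On these data alone, it remains open how a carboxylic acid, a morpholine or a longer chain ending in an amine would fare on this nitrogen.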